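Removing a methoxy from an inactive chalcone

The source may hold more compounds than are shown below. What is called first, only, known or untested is meant among the compounds shown, and "the series" means these compounds.

Compound 1, `COc1ccc(/C=C/C(=O)c2cccc(-c3ccc(F)cc3)c2)cc1`, in an assay on A549 cells for inhibition of transcription factor p65 (Homo sapiens), read by fluorescence, with a stated time of 2 h (a higher number here means a weaker inhibitor, a lower number a stronger inhibitor), gives > 50000 nM, which is a limit of the assay and not a number.
Compound 2, `COc1ccc(/C=C/C(=O)c2cccc(Br)c2)cc1OC`, in this assay gives > 50000 nM, again a limit and not a number.

Compound 2 stands at the same limit as the only other compound measured here, as shown by the limit of > 50000 nM in this assay, at which 2 of the 2 values shown sit. Among the compounds with values here, no measured pair differs in one place, so no measured step is available. The account turns to compound 3, `COc1ccc(/C=C/C(=O)c2cccc(Br)c2)cc1`, which differs from compound 2 by hydrogen in place of methoxy on an aromatic carbon, in words hydrogen in place of methoxy on an aromatic carbon. Since compound 2 sits at a limit in this assay, a change in either direction beyond the scatter could not be read from the numbers, and the expectation is that the limit remains. The estimated step of a number no higher from compound 2 to compound 3 (the limit leaves the size open) is therefore expected to be none beyond the scatter, with the result most likely reported as a limit. Compound 3 is estimated at 50000 nM in this assay, with a range from 15000 nM to 100000 nM.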

Compound 3, half-maximal inhibitory concentration: > 50000 nM
Compound 3: no number, only a limit; the forecaster's own chance of this, stated with the estimate: 80%; the middle value lies on the limit itself.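

No step can be read from compound 2 to compound 3 or from compound 1 to compound 3 in this assay, because all three compounds sit at one limit of the assay and not at a number: the limit of > 50000 nM in this assay, at which 3 of the 3 values shown sit.

The compounds shown leave open how strongly any of them inhibits, and whether hydrogen in place of methoxy changes that at all.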